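Swapping a fluorine for chlorine on the pendant phenyl ring

A few compounds are considered here, and "the series" means these few. Any claim that something is new, unique, unknown or untested is made for them only; others in the source may bear on it.

Compound 3 `O=C(Nc1ccc(Oc2ccnc3[nH]ccc23)c(F)c1)c1cc2cccnc2n(-c2ccc(F)cc2)c1=O` gives 62 nM in a functional assay on A549 cells (Homo sapiens) for antiproliferative activity, read by MTT assay, with a stated time of 72 h (a lower number here means a stronger inhibitor, a higher number a weaker inhibitor), the lowest of the three numbers measured. Its closest neighbour, compound 2 `O=C(Nc1ccc(Oc2ccnc3[nH]ccc23)c(F)c1)c1cc2cccnc2n(-c2ccccc2)c1=O`, gives 190 nM, and the step of a 3.1-fold lower number from compound 2 to compound 3 (0.49 log units; beyond the scatter) shows that adding a fluorine there helped. Compound 1 `O=C(Nc1ccc(Oc2ccnc3[nH]ccc23)cc1)c1cc2cccnc2n(-c2ccc(Cl)cc2)c1=O`, which carries a chloro on that ring but no fluoro on the central ring, gives 290 nM. Compound 4 `O=C(Nc1ccc(Oc2ccnc3[nH]ccc23)c(F)c1)c1cc2cccnc2n(-c2ccc(Cl)cc2)c1=O` differs from compound 3 only by chloro in place of fluoro on an aromatic carbon. Within the data shown here, no measured step isolates this exact change; compound 1 differs from compound 3 in two places, so it offers only a loose hint. Compound 4 is therefore expected to be close to compound 3, with a step of a 1.5-fold higher number from compound 3 to compound 4 (0.16 log units; within the scatter), giving an estimated 90 nM with a range from 35 nM to 250 nM.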

Compound 4, half-maximal inhibitory concentration: 110 nM
For compound 4 the middle estimate is 1.2-fold (0.09 log units) below the measured one, and the stated range covers the measured number.
By their numbers in this assay, from the lowest: compounds 3, 4, 2 and 1 (each within the scatter of the next, the first and the last beyond it).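

Chloro and fluoro on this ring cannot be told apart here, with a 1.8-fold higher number from compound 3 to compound 4 (0.25 log units; within the scatter). Chloro in place of hydrogen on the same ring also stays within the scatter, at a 1.7-fold lower number from compound 2 to compound 4 (0.24 log units; within the scatter), so the clear gain seen earlier with fluoro is not shown for chloro. Fluoro in place of hydrogen gives a 2.6-fold lower number from compound 1 to compound 4 (0.42 log units; beyond the scatter), and that change now reads alike on two cores: the same change on two cores in this assay, a 3.1-fold lower number (0.49 log units; beyond the scatter) from compound 2 to compound 3 and a 2.6-fold lower number (0.42 log units; beyond the scatter) from compound 1 to compound 4, 1.2-fold (0.07 log units) apart, within the scatter of two such steps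

The compounds shown leave open what a group other than a halogen would do at this position, such as a methoxy group or an amine.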